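A Fluoro Step From Compound 3

The source may hold more compounds than are shown below. What is called first, only, known or untested is meant among the compounds shown, and "the series" means these compounds.

Of the compounds shown here, three have been tested so far. In a functional assay on P388 cells (Mus musculus) for inhibition (a lower number here means a stronger inhibitor, a higher number a weaker inhibitor), compound 1 `COc1cc2ccc(CCc3ccc4ccccc4c3)cc2cc1O` gives 3590 nM. Compound 2 `CC(=O)Oc1ccc(/C=C/c2ccc3ccccc3c2)cc1` gives > 5000 nM, which is a limit of the assay and not a number. Compound 3 `COc1cccc(/C=C\c2ccc3ccccc3c2)c1` gives 1920 nM. Compound 3 therefore has one of the two real numbers available, and its value lies within the usual scatter of the value for compound 1, so the two cannot be told apart.

The next compound to be tested is compound 4 `COc1cc(/C=C\c2ccc3ccccc3c2)ccc1F`. It differs from compound 3 in one place: fluoro in place of hydrogen on an aromatic carbon. In words, this is fluoro in place of hydrogen on an aromatic carbon, ortho to a methoxy group and para to a large group.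

For the measured compounds named here, no pair of tested compounds differs in one place, so the data offer no direct measure of such a change. With nothing pointing either way, no shift beyond the scatter is expected in this assay, and the estimate stays close to the value of compound 3, which gives 1920 nM. The expected change is a 1.0-fold higher number from compound 3 to compound 4 (0.02 log units; within the scatter), which is a small step with no firm direction. For compound 4 the estimated value is 2000 nM, with an expected range from 700 nM to 5000 nM.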

Compound 4, half-maximal inhibitory concentration: 450 nM
Compound 4: the middle estimate sits 4.4-fold (0.65 log units) above what was measured, outside the stated range (below it).
By their numbers in this assay, from the lowest: compound 4; then compounds 3 and 1 (each within the scatter of the next). At a limit, above all of these: compound 2.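

Replacing hydrogen with fluoro on an aromatic carbon, ortho to a methoxy group and para to a large group, gives in this assay a 4.3-fold lower number from compound 3 to compound 4 (0.63 log units; beyond the scatter), a modest step that lies beyond the scatter. This is the first direct measure of a change in one place among these compounds, and it shows that this position is not indifferent: a single fluorine atom, with the rest of the structure unchanged, is enough to move the number clearly in the direction of stronger inhibition. Nothing measured here explains why the number falls with this change.

A single step cannot show whether the effect is special to fluoro, or whether a chlorine atom, a methyl group or a hydroxyl group on the same carbon would move the number as far, or further. It also leaves open whether fluoro would give a similar step on another carbon of that ring, or on a version of the shared core that lacks the methoxy group.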